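Working notes: from compound 3 to compound 4

This account rests on a few compounds, and the source may have more. Where it says the series, first, only, none or still open, it means among the compounds named here.

Measured so far in a functional assay on MCF cells (Homo sapiens) for antiproliferative activity, with a stated time of 72 h (a higher number here means a weaker inhibitor, a lower number a stronger inhibitor), as half-maximal inhibitory concentrations
compound 1 `OC[C@H]1O[C@@H](n2cnc3c(NCc4ccccc4Br)ncnc32)[C@H](O)[C@@H]1O` gives > 166000 nM as a limit
compound 2 `OC[C@H]1O[C@@H](n2cnc3c(NCc4ccc(Cl)c(Cl)c4)ncnc32)[C@H](O)[C@@H]1O` gives 88800 nM as a number
compound 3 `COc1cc(CNc2ncnc3c2ncn3[C@@H]2O[C@H](CO)[C@@H](O)[C@H]2O)cc(OC)c1` gives > 166000 nM as a limit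

Compound 3 stands at the limit of > 166000 nM in this assay, at which 2 of the 3 values shown sit, and so has a limit, not a number. The change to compound 4 `OC[C@H]1O[C@@H](n2cnc3c(NCc4cccc(O)c4O)ncnc32)[C@H](O)[C@@H]1O` is 2,3-dihydroxyphenyl in place of 3,5-dimethoxyphenyl on a saturated chain carbon bound to a nitrogen on an aromatic ring and replaces 3,5-dimethoxyphenyl with 2,3-dihydroxyphenyl. The measured steps bearing on it are an at least 1.8-fold lower number from compound 1 to compound 2 (0.27 log units; that floor lies within the scatter) and an at least 1.8-fold higher number from compound 2 to compound 3 (0.27 log units; that floor lies within the scatter), both with floors within the scatter, while a step that the two limits leave unreadable from compound 1 to compound 3 cannot be sized. No step beyond the scatter is therefore expected in this assay for this change. The estimated step is an at least 1.2-fold lower number from compound 3 to compound 4 (0.10 log units; that floor lies within the scatter) and is expected to stay within the scatter. Compound 4 is estimated at 130000 nM, with an expected range of 70000 nM to 250000 nM and a real chance of only a limit.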

Compound 4, half-maximal inhibitory concentration: 5200 nM
The estimate for compound 4 lay 25-fold (1.40 log units) above the measured number; the whole stated range lies above it.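

In this assay, within the data shown here, 2,3-dihydroxyphenyl on a saturated chain carbon bound to a nitrogen on an aromatic ring gives steps beyond the scatter, which the earlier compounds did not show: an at least 31-fold lower number from compound 3 to compound 4 (1.50 log units; beyond the scatter), a 17-fold lower number from compound 2 to compound 4 (1.23 log units; beyond the scatter) and an at least 31-fold lower number from compound 1 to compound 4 (1.50 log units; beyond the scatter). Among these compounds, compound 4 is therefore the strongest of the four, and the only one with hydroxyl groups on the phenyl ring. The steps from compound 1 and compound 3 are floors, as each of these compounds gives a limit, not a number: the limit of > 166000 nM in this assay, at which 2 of the 4 values shown sit.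

The step between compound 1 and compound 3 cannot be read. On these data alone, whether a single hydroxyl group, or an amine in place of the hydroxyl groups, would keep this gain remains open.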